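Nitro in place of bromo in compound 2

The source may report more compounds than this note shows. Statements on the series, on what has been measured and on what is new or still open speak of the compounds shown alone.

In a functional assay on NCI-H460 cells (Homo sapiens) for inhibition, read by sulforhodamine B assay, with a stated time of 48 h (a lower number here means a stronger inhibitor of growth, a higher number a weaker inhibitor of growth), compound 2 (`N#CCC1=C(C#N)CC(c2ccc(Br)cc2)=C(CC(=O)c2ccc(Br)cc2)O1`) gives 10400 nM and compound 1 (`N#CCC1=NN=C(c2ccc([N+](=O)[O-])cc2)C(CC(=O)c2ccc([N+](=O)[O-])cc2)O1`) gives 2600 nM. The number of compound 2 is the higher of the two, and the gap between them lies beyond the scatter. Compound 3 (`N#CCC1=C(C#N)CC(c2ccc([N+](=O)[O-])cc2)=C(CC(=O)c2ccc(Br)cc2)O1`) keeps the core of compound 2 but has nitro in place of bromo on an aromatic carbon, para to a large group: nitro in place of bromo on an aromatic carbon. Compound 1 also carries nitro, but its core differs, so its 2600 nM is only a weak guide. A small step towards a lower number, within the scatter, is expected: a 1.6-fold lower number from compound 2 to compound 3 (0.20 log units; within the scatter). The estimate for compound 3 is 6500 nM, with an expected range of 2500 nM to 16000 nM.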

Compound 3, concentration for 50% growth inhibition: 3600 nM
For compound 3 the middle estimate is 1.8-fold (0.26 log units) above the measured one; low and high end bracket the measured number.
By their numbers in this assay, from the lowest: compounds 1 and 3 (each within the scatter of the next); then compound 2.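

In this assay the change from 4-bromophenyl to 4-nitrophenyl gives a 2.9-fold lower number from compound 2 to compound 3 (0.46 log units; beyond the scatter) with the rest of the structure kept, including the other 4-bromophenyl group. Among the compounds shown here, this is the only single-place comparison so far, and it shows that the number responds to the group at this position by more than the scatter. Nothing measured here gives a reason for the step. Open questions are whether an amine or a carboxylic acid at this position would shift the number, and whether nitro on the other 4-bromophenyl group would give a similar step.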